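Replacing 3-chlorophenyl with methyl on the sulfonyl sulfur

A few compounds are considered here, and "the series" means these few. Any claim that something is new, unique, unknown or untested is made for them only; others in the source may bear on it.

Values in an ADME assay on HEK293 cells (Homo sapiens) for cytotoxicity, read by resazurin assay, with a stated time of 48 h (on this read-out higher numbers stand for lower toxicity in this test and lower numbers for higher toxicity in this test), follow, each a limit and not a number:
- compound 1 `O=S(=O)(Nc1ccc(-c2nc3ccccc3o2)cc1)c1cccc(F)c1` gives > 100000 nM as a limit
- compound 2 `O=S(=O)(Nc1ccc(-c2nc3ccccc3o2)cc1)c1ccccc1Cl` gives > 100000 nM as a limit
- compound 3 `O=S(=O)(Nc1ccc(-c2nc3ccccc3o2)cc1)c1cccc(Cl)c1` gives > 100000 nM as a limit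

Compound 3 thus has no number of its own and shares its reading with the other two (the limit of > 100000 nM in this assay, at which 3 of the 3 values shown sit). Compound 4 `CS(=O)(=O)Nc1ccc(-c2nc3ccccc3o2)cc1` carries methyl in place of 3-chlorophenyl on a sulfonyl sulfur and keeps the shared core.

The measured changes to this group are a step that the two limits leave unreadable from compound 1 to compound 3 and a step that the two limits leave unreadable from compound 2 to compound 3 and neither gives a size. Among the measured compounds shown here, no measured compound lacks the aromatic ring on the sulfur. Given the limit of > 100000 nM in this assay, at which 3 of the 3 values shown sit, no step beyond the scatter is expected in this assay and a report at the same limit is the likeliest outcome. The expected step is a number no higher from compound 3 to compound 4 (the limit leaves the size open) and it rests on that limit alone. For compound 4 the estimate is 100000 nM with an expected range of 40000 nM to 250000 nM overall.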

Compound 4, half-maximal cytotoxic concentration: > 100000 nM
Compound 4 gave a limit, no number; the forecaster's own chance of this, stated with the estimate: 85%; the middle value sits exactly at the limit.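

No step can be read between compound 4 and compound 1, compound 2 or compound 3 in this assay, and the shared reading is a limit, not a number: the limit of > 100000 nM in this assay, at which 4 of the 4 values shown sit.

The compounds shown leave open whether any group on the sulfonyl sulfur changes the half-maximal cytotoxic concentration.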